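Urea aryl variation on a shared core: outlook for compound 4

A few compounds are considered here, and "the series" means these few. Any claim that something is new, unique, unknown or untested is made for them only; others in the source may bear on it.

Among the compounds with values here, the three measured members share one core and differ only in the aryl group on the far end of the urea. Compound 1 `COc1cc(Cl)cc(-c2nn(-c3cccc(NC(=O)Nc4ccc(Cl)c(C(F)(F)F)c4)c3)cc2-c2ccncc2)c1`, compound 2 `COc1cc(Cl)cc(-c2nn(-c3cccc(NC(=O)Nc4cc(C(F)(F)F)cc(C(F)(F)F)c4)c3)cc2-c2ccncc2)c1` and compound 3 `COc1cc(Cl)cc(-c2nn(-c3cccc(NC(=O)Nc4ccc(Cl)c(Cl)c4)c3)cc2-c2ccncc2)c1` have all been run in a functional assay on MDA-MB-435 cells (Homo sapiens) for inhibition, read by sulforhodamine B assay, with a stated time of 48 h, tested at 0.01 uM; on this read-out lower numbers stand for a stronger effect and higher numbers for a weaker effect at the one concentration tested. In this assay compound 1 gives 95%, compound 2 gives 97% and compound 3 gives 93%. Compound 3 holds the lowest of the three numbers, but its gaps to compound 1 and to compound 2 both lie within the scatter, so no order among the three can be read. Within the data shown here, the one single-point step available, a number 2 percentage points lower from compound 1 to compound 3 (within the scatter), is likewise within the scatter.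

Compound 4 `COc1cc(Cl)cc(-c2nn(-c3cccc(NC(=O)Nc4cccc(C(F)(F)F)c4)c3)cc2-c2ccncc2)c1` has not yet been measured. Its difference from compound 3 is 3-(trifluoromethyl)phenyl in place of 3,4-dichlorophenyl on an amide-type nitrogen. Among the measured compounds shown here, no measured step matches this change directly; the step of a number 2 percentage points lower from compound 1 to compound 3 (within the scatter) touches the same aryl group and shows no movement beyond the scatter, and all three measured values sit close together at the weak end of the read-out. The expected step of a number 1 percentage points higher from compound 3 to compound 4 (within the scatter) is therefore none beyond the scatter. Compound 4 is estimated at 94%, within a range from 82% to 102%.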

Compound 4, a percentage reported as activity, at one concentration (the size of the read-out at that concentration, not a potency): 100%
For compound 4 the middle estimate is 6 percentage points below the measured one, and the stated range covers the measured number.
By their numbers in this assay, from the lowest: compounds 3, 1, 2 and 4 (each within the scatter of the next).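

Within the data shown here, compound 4 carries one substituent on the urea aryl ring, whereas compounds 1, 2 and 3 each carry two, so it is the first test of whether the second substituent can be removed in this assay. Removing it leaves the read-out within the scatter whichever group goes: hydrogen in place of trifluoromethyl gives a number 3 percentage points higher from compound 2 to compound 4 (within the scatter), and hydrogen in place of chloro gives a number 5 percentage points higher from compound 1 to compound 4 (within the scatter), while replacing 3,4-dichlorophenyl with 3-(trifluoromethyl)phenyl on the amide-type nitrogen gives a number 7 percentage points higher from compound 3 to compound 4 (within the scatter), so none of these changes to the aryl group can be read as a real shift at the one concentration tested. No measurement at hand accounts for this result or bears on it.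

All four compounds remain within the scatter of one another at the weak end of the read-out, so this single concentration gives no ranking of the aryl groups. Still open, from the compounds shown here alone, is whether an amine or a carboxylic acid on this aryl ring, or a cyclohexyl group in its place, would move the number beyond the scatter.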